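Moving the chlorine on the benzylsulfanyl group of the shared core

The source may hold more compounds than are shown below. What is called first, only, known or untested is meant among the compounds shown, and "the series" means these compounds.

Measured compounds:
compound 1 `COc1ccc(C2N=C(SCc3ccc(Cl)cc3)NC(C)=C2C(=O)Nc2ccc(F)cc2)cc1OC` — 5.7%
compound 2 `CC1=C(C(=O)Nc2ccc(F)cc2)C(c2ccc([N+](=O)[O-])cc2)N=C(SCc2ccccc2Cl)N1` — 3.1%
compound 3 `CC1=C(C(=O)Nc2ccc(F)cc2)C(c2ccc([N+](=O)[O-])cc2)N=C(SCc2cccc(Cl)c2)N1` — 4.1%

All three compounds were tested in a functional assay on the whole organism (artery, strain albino) with Rattus norvegicus as the target, with a stated time of 30 min, at a dose of 10 mg/kg by the oral route (on this read-out higher numbers stand for more inhibition at the one dose given (going by the name of the read-out) and lower numbers for less inhibition), and in this assay compound 3 gives 4.1%. Its nearest neighbour is compound 2 and its furthest is compound 1, yet both gaps lie within the usual scatter, so the three numbers cannot be told apart: the whole set shows only weak inhibition at the dose given.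

Compound 4 `CC1=C(C(=O)Nc2ccc(F)cc2)C(c2ccc([N+](=O)[O-])cc2)N=C(SCc2ccc(Cl)cc2)N1` is the next member of the series. It differs from compound 3 by 4-chlorophenyl in place of 3-chlorophenyl on a saturated chain carbon bound to a sulfur.

Among the measured compounds shown here, only one measured step bears on this change. The step of a number 1 percentage points higher from compound 2 to compound 3 (within the scatter) also altered nothing but the chlorophenyl on that carbon, and it stayed within the scatter. Compound 1 already carries a 4-chlorophenyl at the same place, though its core bears a different aryl group. Compound 1 gives 5.7% and compound 3 gives 4.1%; the two values show the same low band.

Compound 4 is therefore expected to show a number 0.4 percentage points higher from compound 3 to compound 4 (within the scatter), that is, no step beyond the scatter. The estimate for compound 4 is 4.5%, with a range from 0% to 12%.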

Compound 4, a percentage reported as inhibition, in the whole organism at one dose (the size of the read-out at that dose, not a potency): 6.7%
Compound 4: the middle estimate sits 2.2 percentage points below what was measured; the range from low to high includes it.
By their numbers in this assay, from the lowest: compounds 2, 3, 1 and 4 (each within the scatter of the next).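

With compound 4, the 2-chlorophenyl, 3-chlorophenyl and 4-chlorophenyl groups can all be compared on the same core, and in this assay the change to 4-chlorophenyl gives a number 2.6 percentage points higher from compound 3 to compound 4 (within the scatter) and a number 3.6 percentage points higher from compound 2 to compound 4 (within the scatter). The aryl group on the saturated ring carbon can now also be read on its own with the 4-chlorophenyl held fixed: 4-nitrophenyl in place of 3,4-dimethoxyphenyl gives a number 1 percentage points higher from compound 1 to compound 4 (within the scatter). Neither the place of the chlorine nor this exchange on the ring carbon separates these compounds, so all four stay in one low band of inhibition at the single dose.

On these data alone, what stays open is whether a different kind of group could lift the inhibition out of that band, such as a carboxylic acid or an amine in place of the chlorine, or a longer chain in place of the benzyl on the sulfur. Nothing available accounts for where these values fall.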